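The source may report more compounds than this note shows. Statements on the series, on what has been measured and on what is new or still open speak of the compounds shown alone.

Compound 2 `CC(C)=CCc1cc(C(=O)Nc2cc3ccc(OCCCNC(C)C)c(C)c3oc2=O)ccc1O` gives the lowest of the two numbers in a functional assay on MCF7 cells (Homo sapiens) for antiproliferative activity (a lower number here means a stronger inhibitor, a higher number a weaker inhibitor), at 740 nM. Compound 1 `CCCNCCCOc1ccc2cc(NC(=O)c3ccc(O)c(CC=C(C)C)c3)c(=O)oc2c1C` gives 980 nM in this assay, and the step of a 1.3-fold lower number from compound 1 to compound 2 (0.12 log units; within the scatter) lies within the scatter. In this assay compound 3 `CC(C)=CCc1cc(C(=O)Nc2cc3ccc(OCCCN(C)c4ccccc4)c(C)c3oc2=O)ccc1O` gives > 50000 nM, which is a limit of the assay and not a number. Compound 4 `CC(C)=CCc1cc(C(=O)Nc2cc3ccc(OCCCNC(C)(C)c4ccccc4)c(C)c3oc2=O)ccc1O` differs from compound 2 by phenyl in place of hydrogen on a saturated chain carbon bound to an amine nitrogen and two saturated chain carbons. For the measured compounds named here, the steps that bear on it place a phenyl on the amine side of the chain: an at least 67-fold higher number from compound 2 to compound 3 (1.82 log units; beyond the scatter) and an at least 51-fold higher number from compound 1 to compound 3 (1.70 log units; beyond the scatter), both running to the limit of > 50000 nM in this assay, at which 1 of the 3 values shown sits. Compound 4 puts the phenyl one carbon away from the nitrogen, so a smaller but still clear loss is expected, an 11-fold higher number from compound 2 to compound 4 (1.03 log units; beyond the scatter), giving an estimated 8000 nM with a range from 1500 nM to 50000 nM.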

Compound 4, half-maximal inhibitory concentration: 1070 nM
For compound 4 the middle estimate is 7.5-fold (0.87 log units) above the measured one, and the stated range ends above it.
By their numbers in this assay, from the lowest: compounds 2, 1 and 4 (each within the scatter of the next). At a limit, above all of these: compound 3.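

On the saturated chain carbon bound to an amine nitrogen and two saturated chain carbons, phenyl is tolerated in this assay: a 1.4-fold higher number from compound 2 to compound 4 (0.16 log units; within the scatter), and a 1.1-fold higher number from compound 1 to compound 4 (0.04 log units; within the scatter). A phenyl in this side chain therefore does not by itself abolish activity, as an at least 46-fold lower number from compound 3 to compound 4 (1.66 log units; beyond the scatter) also shows. The value of compound 3 is a limit of the assay and not a number: the limit of > 50000 nM in this assay, at which 1 of the 4 values shown sits.

On these data alone, it remains open whether a cyclohexyl or a substituted phenyl would be tolerated on this carbon. A phenylamino or a dimethylamino group would be needed to separate the contributions of the methyl and the phenyl in compound 3.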